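Moving the methyl group on the outer phenyl ring

The compounds below may be only part of what the source reports. "The series", "measured", "known", "first", "only" and "open" are said of these compounds alone.

Measured in a functional assay on J774 cells (Mus musculus) for cytotoxicity, read by resazurin assay; a higher number here means a weaker inhibitor, a lower number a stronger inhibitor:
- compound 1 `OCCCCCC(O)c1ccc(-c2ccc(Br)cc2)cc1`: 20000 nM
- compound 2 `OCCCCCC(O)c1ccc(-c2ccc(F)cc2)cc1`: 18000 nM
- compound 3 `Cc1cccc(-c2ccc(C(O)CCCCCO)cc2)c1`: > 100000 nM

Compound 3 has no number, only (the limit of > 100000 nM in this assay, at which 1 of the 3 values shown sits). Compound 4 `Cc1ccc(-c2ccc(C(O)CCCCCO)cc2)cc1` carries 4-methylphenyl in place of 3-methylphenyl on an aromatic carbon. Going by the values given here, two measured steps bear on this change, both ending at compound 3 and both reaching it from a 4-substituted phenyl: an at least 5.0-fold higher number from compound 1 to compound 3 (0.69 log units; beyond the scatter) and an at least 5.5-fold higher number from compound 2 to compound 3 (0.74 log units; beyond the scatter). Swapping the 4-substituent itself gave a 1.1-fold lower number from compound 1 to compound 2 (0.05 log units; within the scatter). A reversal of those two steps is therefore expected, with a lower number in this assay. The expected step is an at least 3.3-fold lower number from compound 3 to compound 4 (0.52 log units; beyond the scatter). Compound 4 is estimated at 30000 nM, with an expected range of 12000 nM to 90000 nM.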

Compound 4, half-maximal inhibitory concentration: 22000 nM
Compound 4: middle estimate off by 1.4-fold (0.13 log units), on the high side, and the stated range covers the measured number.
By their numbers in this assay, from the lowest: compounds 2, 1 and 4 (each within the scatter of the next). At a limit, above all of these: compound 3.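

In this assay, moving the methyl group to give 4-methylphenyl produces an at least 4.5-fold lower number from compound 3 to compound 4 (0.65 log units; beyond the scatter), so the place of the methyl group on the outer ring matters, though compound 3 stands only at a limit: the limit of > 100000 nM in this assay, at which 1 of the 4 values shown sits.

With a 4-substituted ring, exchanging the group changes little: a 1.2-fold higher number from compound 2 to compound 4 (0.09 log units; within the scatter) and a 1.1-fold higher number from compound 1 to compound 4 (0.04 log units; within the scatter), both within the scatter. Methyl thus reads like fluoro and bromo there, and only 3-methylphenyl stands apart.

Going by these compounds, whether 3-fluorophenyl or 3-bromophenyl departs as far stays open, as does what an amine or a carboxylic acid would do in place of the methyl group.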